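This account rests on a few compounds, and the source may have more. Where it says the series, first, only, none or still open, it means among the compounds named here.

In a functional assay on MCF7 cells (Homo sapiens) for antiproliferative activity, read by MTT assay, with a stated time of 48 h (on this read-out higher numbers stand for weaker inhibition and lower numbers for stronger inhibition), the measured members of the series stand as follows:

compound 1 `Cc1cc2nc(-c3cn(-c4ccccc4)nc3-c3ccccc3)[nH]c2cc1C` gives > 50000 nM, a limit of the assay.
compound 2 `Cc1cc2nc(-c3cn(-c4ccccc4)nc3-c3ccc(F)cc3)[nH]c2cc1C` gives 27200 nM.
compound 3 `Clc1ccc(-c2nn(-c3ccccc3)cc2-c2nc3ccccc3[nH]2)cc1` gives 3030 nM.

Compound 1 and compound 2 differ by fluoro in place of hydrogen on an aromatic carbon, and the step is an at least 1.8-fold lower number from compound 1 to compound 2 (0.26 log units; that floor lies within the scatter). Compound 1 sits at the limit of > 50000 nM in this assay, at which 1 of the 3 values shown sits, so that step is known only as a floor. How the core of compound 3 differs from the core of compound 1 is not broken down here; the two values show compound 3 with the lower number of the two.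

Compound 4 `Fc1ccc2[nH]c(-c3cn(-c4ccccc4)nc3-c3ccc(Cl)cc3)nc2c1` differs from compound 3 by fluoro in place of hydrogen on an aromatic carbon. This is the same kind of change as that from compound 1 to compound 2, not the same: in compound 2 the fluoro sits para to a large group, whereas in compound 4 it sits on a ring that is part of a fused or bridged system of two rings, meta to a fused ring and para to a fused ring. Among the measured compounds shown here, since the earlier step was within the scatter, a step of similar size is expected from compound 3 to compound 4, a 1.4-fold lower number from compound 3 to compound 4 (0.14 log units; within the scatter), because an at least 1.8-fold lower number from compound 1 to compound 2 (0.26 log units; that floor lies within the scatter) gives the only guide. Compound 4 is accordingly estimated at 2200 nM, between 800 nM and 7000 nM.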

Compound 4, half-maximal inhibitory concentration: 2830 nM
Compound 4: the middle estimate sits 1.3-fold (0.11 log units) below what was measured; measured number inside the range.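

In this assay, among the compounds shown here, fluoro in place of hydrogen on an aromatic carbon, here on the ring that is part of a fused or bridged system of two rings, gives a 1.1-fold lower number from compound 3 to compound 4 (0.03 log units; within the scatter), so on the core of compound 3 the change leaves no step that stands clear of the scatter. Set beside the earlier case, the step offers no sign of a gain that carries from one core to the other, yet the two cases cannot be called equal: the same change on two cores in this assay, an at least 1.8-fold lower number (0.26 log units; that floor lies within the scatter) from compound 1 to compound 2 and a 1.1-fold lower number (0.03 log units; within the scatter) from compound 3 to compound 4; the limit leaves it open whether they differ Nor does the pair show that the change is without effect on the core of compound 1, since the value of compound 1 is a limit and not a number: the limit of > 50000 nM in this assay, at which 1 of the 4 values shown sits.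

Still open is whether fluoro would read the same at other aromatic carbons of these compounds, or on further cores. Also open, going by these compounds, is whether a different group on these rings, such as an amine, a carboxylic acid or a longer chain, would give a step beyond the scatter.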